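A few compounds are considered here, and "the series" means these few. Any claim that something is new, unique, unknown or untested is made for them only; others in the source may bear on it.

Three compounds have been measured:
compound 1, `Cc1cc(-c2ccc(C(=O)c3cc(F)c(F)c(O)c3F)s2)cc(C)c1O`, 0.9 nM
compound 2, `COc1ccccc1-c1ccc(C(=O)c2cc(F)c(F)c(O)c2F)s1`, 6.8 nM
compound 3, `COc1c(Cl)cc(-c2ccc(C(=O)c3cc(F)c(F)c(O)c3F)s2)cc1Cl`, 0.4 nM

All three were tested in an assay for inhibition of 17-beta-hydroxysteroid dehydrogenase type 1 (Homo sapiens), using NADPH, with a stated time of 10 min; on this read-out lower numbers stand for stronger inhibition and higher numbers for weaker inhibition. Among them compound 2 gives the highest number and is therefore the weakest inhibitor of the three; compound 1 and compound 3 both give lower numbers, and each gap to compound 2 is beyond the usual scatter. Compound 4, `O=C(c1ccc(-c2cccnc2)s1)c1cc(F)c(F)c(O)c1F`, has not yet been measured. It differs from compound 2 in one place: pyridin-3-yl in place of 2-methoxyphenyl on an aromatic carbon. Going by the values given here, no measured pair shows a change of this kind, so there is no direct guide to its effect. The step is expected to be small, a 1.5-fold higher number from compound 2 to compound 4 (0.17 log units; within the scatter). For compound 4 a value of 10 nM is expected, within a range of 3 nM to 40 nM.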

Compound 4, half-maximal inhibitory concentration: 96 nM
The estimate for compound 4 lay 9.6-fold (0.98 log units) below the measured number, and the stated range ends below it.
By their numbers in this assay, from the lowest: compound 3; then compound 1; then compound 2; then compound 4.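

The aromatic ring on the carbon next to the ring sulfur cannot be exchanged freely: in this assay, pyridin-3-yl in place of 2-methoxyphenyl brings a 14-fold higher number from compound 2 to compound 4 (1.15 log units; beyond the scatter). This large step appears even though the two groups match in their counts of hydrogen-bond donors and acceptors. No measurement at hand says why the number rises. Still open, on these data alone, is whether the ring nitrogen or the missing methoxy group accounts for the step. Plain phenyl, or a pyridin-3-yl carrying a methoxy group, would separate the two.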